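Compound 3 to compound 4: side chain notes

A few compounds are considered here, and "the series" means these few. Any claim that something is new, unique, unknown or untested is made for them only; others in the source may bear on it.

Within the data shown here, in a functional assay on SH-SY5Y cells (Homo sapiens) for cytotoxicity, read by MTT assay, with a stated time of 72 h (a higher number here means a weaker inhibitor, a lower number a stronger inhibitor), compound 3 (`O=C1c2c[n+]([O-])c3ccccc3c2C(=O)c2c1c1ccccc1n2CCCCN1CCCCC1`) gives 230 nM, the lowest of the three numbers so far. Compound 2 (`CC1(C)OC[C@H](Cn2cc(Cn3c4c(c5ccccc53)C(=O)c3c[n+]([O-])c5ccccc5c3C4=O)nn2)O1`) gives 820 nM, and compound 1 (`CCCCN1CCN(CCCCn2c3c(c4ccccc42)C(=O)c2c[n+]([O-])c4ccccc4c2C3=O)CC1`) gives 6100 nM.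

The next compound is compound 4 (`CN1CCN(CCCCCn2c3c(c4ccccc42)C(=O)c2c[n+]([O-])c4ccccc4c2C3=O)CC1`), with (4-methylpiperazin-1-yl)methyl in place of piperidin-1-yl on a saturated chain carbon, four bonds along the chain from an aromatic nitrogen. Cut one bond further out, this reads 3-(piperidin-1-yl)propyl to 4-(4-methylpiperazin-1-yl)butyl.

Among the measured compounds shown here, the only measured step that bears on this change is a 27-fold lower number from compound 1 to compound 3 (1.42 log units; beyond the scatter), with piperidin-1-yl in place of 4-butylpiperazin-1-yl. Going back to a piperazine is expected to undo part of that step, though not all of it. For the measured compounds named here, no measured pair isolates the butyl group on the piperazine or the longer chain, so the range stays wide.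

The expected change, towards a higher number in this assay, is a 6.1-fold higher number from compound 3 to compound 4 (0.78 log units; beyond the scatter). For compound 4 the estimated value is 1400 nM, with an expected range of 400 nM to 5000 nM.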

Compound 4, half-maximal inhibitory concentration: 830 nM
For compound 4 the middle estimate is 1.7-fold (0.23 log units) above the measured one, and the stated range covers the measured number.
By their numbers in this assay, from the lowest: compound 3; then compounds 2 and 4 (each within the scatter of the next); then compound 1.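

In this assay the piperazine side chains do not sit at one level: a 7.3-fold lower number from compound 1 to compound 4 (0.87 log units; beyond the scatter) with (4-methylpiperazin-1-yl)methyl in place of 4-butylpiperazin-1-yl, so a change that keeps the piperazine ring still moves the number beyond the scatter. Piperidin-1-yl keeps the lower number against this second piperazine too, with a 3.6-fold higher number from compound 3 to compound 4 (0.56 log units; beyond the scatter) for the swap to (4-methylpiperazin-1-yl)methyl. Nothing in the available data explains either step.

Both steps alter the chain length and the ring or its substituent together, so the compounds shown cannot assign either step to one of these features alone. Piperidin-1-yl on the longer chain, 4-methylpiperazin-1-yl on the shorter chain, and a morpholine in place of either ring remain open.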